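The compounds below may be only part of what the source reports. "The series", "measured", "known", "first", "only" and "open" are said of these compounds alone.

Measured so far in a functional assay on PC-3 cells (Homo sapiens) for inhibition, read by MTT assay, with a stated time of 48 h; on this read-out higher numbers stand for weaker inhibition of growth and lower numbers for stronger inhibition of growth:
compound 1 `C#CCN(C)Cc1ccc(NC(=O)CCCCCCC(=O)NO)cc1` — 2280 nM
compound 2 `C#CCN(C)Cc1ccc(NC(=O)CCCCCCCC(=O)NO)cc1` — 7160 nM

Compound 2 stands highest of the two numbers; compound 1 gives 2280 nM, the nearer and only other point. Compound 3 `C#CCN(C)Cc1ccc(NC(=O)CCCCCCCCC(=O)NO)cc1` differs from compound 2 by (hydroxycarbamoyl)methyl in place of hydroxycarbamoyl on a saturated chain carbon, seven bonds along the chain from a carbonyl carbon. Among the compounds with values here, the only step that bears on this is the same change cut one bond further in, a 3.1-fold higher number from compound 1 to compound 2 (0.50 log units; beyond the scatter), a modest loss beyond the scatter. A further rise of comparable size is expected, a 2.2-fold higher number from compound 2 to compound 3 (0.35 log units; beyond the scatter), though with one step the size is uncertain. Compound 3 is therefore estimated at 16000 nM, with a range from 6000 nM to 45000 nM.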

Compound 3, concentration for 50% growth inhibition: 4260 nM
Compound 3: the middle estimate sits 3.8-fold (0.57 log units) above what was measured; measured number outside the range, below it.
By their numbers in this assay, from the lowest: compounds 1, 3 and 2 (each within the scatter of the next, the first and the last beyond it).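

In this assay, the change to (hydroxycarbamoyl)methyl at this position, seven bonds along the chain from a carbonyl carbon, gives a 1.7-fold lower number from compound 2 to compound 3 (0.23 log units; within the scatter), while the comparison across both chain extensions gives a 1.9-fold higher number from compound 1 to compound 3 (0.27 log units; within the scatter). The step seen one bond further in therefore does not continue as a steady trend: compound 3 goes against it, lying within the scatter of both neighbours. No measurement at hand accounts for this. Still open, as far as these compounds go, are whether a longer chain stays in this range and how a carboxylic acid in place of hydroxycarbamoyl would read.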